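The compounds below may be only part of what the source reports. "The series", "measured", "known", "first", "only" and "open" are said of these compounds alone.

Compound 1 `CCC(COc1ccccc1)OC(=O)NCc1ccccc1` and compound 2 `CCC(COc1cccc(C)c1)OC(=O)NCc1ccccc1` share one core and differ only on the aromatic ring. In an assay for inhibition of zeta-carotene desaturase, chloroplastic/chromoplastic (Capsicum annuum), using a Dixon plot, with a stated time of 8 h (a higher number here means a weaker inhibitor, a lower number a stronger inhibitor), compound 1 gives > 100000 nM, which is a limit of the assay and not a number. In this assay compound 2 gives > 100000 nM, likewise a limit. The step that the two limits leave unreadable from compound 1 to compound 2 is therefore not readable in size or direction. Compound 2 stands at the limit of > 100000 nM in this assay, at which 2 of the 2 values shown sit, so no number separates it from compound 1.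

Compound 3 `CCC(COc1cccc(C(=O)O)c1)OC(=O)NCc1ccccc1` differs from compound 2 by carboxy in place of methyl on an aromatic carbon. Among the compounds with values here, the single measured step concerns the same aromatic carbon, but as its size cannot be read it gives no guide in either direction. The expected step of a number no higher from compound 2 to compound 3 (the limit leaves the size open) is accordingly set at none beyond the scatter, with a further limit the most probable outcome. Compound 3 is estimated in this assay at 100000 nM, with a range from 10000 nM to 1000000 nM.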

Compound 3, half-maximal inhibitory concentration: > 100000 nM
Compound 3 ended at the assay's limit (the forecaster's own chance of this, stated with the estimate: 80%); the middle value lies on the limit itself.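

Within the data shown here, no step among compound 1, compound 2 and compound 3 can be read in this assay, as all three stand at a limit of the assay and not at a number: the limit of > 100000 nM in this assay, at which 3 of the 3 values shown sit. The compounds shown leave open whether any change on the aromatic ring of the shared core gives a readable value in this assay.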